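A few compounds are considered here, and "the series" means these few. Any claim that something is new, unique, unknown or untested is made for them only; others in the source may bear on it.

Measured so far:
compound 1 `C=CCNC(=O)n1c(-c2ccc(OC)cc2)cc(=O)c2c(OC)cc(OC)cc21` gives 12000 nM
compound 2 `COc1ccc(-c2c(I)c(=O)c3c(OC)cc(OC)cc3n2S(=O)(=O)c2ccc(OC)cc2)cc1` gives 8580 nM

In a functional assay on KOPN-8 cells (Homo sapiens) for antiproliferative activity, with a stated time of 72 h (a lower number here means that less compound is needed, a higher number that more compound is needed for the effect), compound 1 stands with the higher of the two numbers, but the value of compound 2 lies within the scatter of it, so the two cannot be told apart on these data. Compound 3 `COc1ccc(-c2cc(=O)c3c(OC)cc(OC)cc3n2S(=O)(=O)c2cccc(Br)c2)cc1` has not been measured. It differs from compound 1 in one place: (3-bromophenyl)sulfonyl in place of allylcarbamoyl on an aromatic nitrogen. Compound 2 also carries an arylsulfonyl on that nitrogen, yet it differs from compound 3 in more than that one place, so its number gives only a loose guide. Among the measured compounds shown here, with no measured step of this kind to lean on, the step in this assay is expected to be small, at most a modest move toward a lower number, and possibly none beyond the scatter. For compound 3 the estimated value is 7000 nM (range 2500 nM to 20000 nM), an expected step of a 1.7-fold lower number from compound 1 to compound 3 (0.23 log units; within the scatter).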

Compound 3, half-maximal effective concentration: > 58600 nM
Compound 3 ended at the assay's limit (the forecaster's own chance of this, stated with the estimate: 10%); middle value at least 8.3-fold (0.92 log units) away from the limit.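

In this assay compound 3 gives > 58600 nM, which is a limit of the assay and not a number: the limit of > 58600 nM in this assay, at which 1 of the 3 values shown sits. Placing (3-bromophenyl)sulfonyl in place of allylcarbamoyl on the aromatic nitrogen gives an at least 4.8-fold higher number from compound 1 to compound 3 (0.68 log units; beyond the scatter), the first single change that can be read at this position. The step shows that the assay responds to what sits on this nitrogen, which the two earlier compounds, whose numbers could not be told apart, did not show.

On these data alone, how far the number of compound 3 lies past the limit remains open, so the step has only a lower bound. Also open, as far as these compounds go, is whether the sulfonyl link or the 3-bromophenyl ring goes with the higher number, which a methylsulfonyl group or an unsubstituted phenylsulfonyl group on the same nitrogen could separate.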